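Chromene chalcones: pyridyl replacement of the methoxyphenyl arm

A few compounds are considered here, and "the series" means these few. Any claim that something is new, unique, unknown or untested is made for them only; others in the source may bear on it.

Compound 1, `COc1cccc(/C=C/C(=O)c2ccc(OC)c3c2OC(C)(C)C=C3)c1`: in a functional assay on HepG2 cells (Homo sapiens) for antiproliferative activity, read by MTT assay, with a stated time of 24 h (on this read-out higher numbers stand for weaker inhibition and lower numbers for stronger inhibition), compound 1 gives > 10000 nM.
Compound 2, `COc1ccc(C(=O)/C=C/c2ccc(N(c3ccccc3)c3ccccc3)cc2)c2c1C=CC(C)(C)O2`: in this assay compound 2 gives > 10000 nM.
Compound 3, `COc1ccc(C(=O)/C=C/c2ccc3ccccc3n2)c2c1C=CC(C)(C)O2`: in this assay compound 3 gives 4280 nM.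

For compound 1 the value is a limit of the assay, not a number. It sits at the limit of > 10000 nM in this assay, at which 2 of the 3 values shown sit. Compound 3 alone returns a number. Among the compounds with values here, no two measured compounds differ in only one place, so no measured step is available.

Compound 4, `COc1ccc(/C=C/C(=O)c2ccc(OC)c3c2OC(C)(C)C=C3)cn1`, is not yet measured. It differs from compound 1 by 6-methoxypyridin-3-yl in place of 3-methoxyphenyl on a double-bonded chain carbon bound to a double-bonded chain carbon.

With compound 1 at the limit, the step from compound 1 to compound 4 is expected to be small, likely within the scatter, and compound 4 is expected to give 15000 nM (range 5000 nM to 50000 nM), a step that the limit leaves unreadable from compound 1 to compound 4.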

Compound 4, half-maximal inhibitory concentration: > 10000 nM
Compound 4 gave a limit, no number (the forecaster's own chance of this, stated with the estimate: 70%); the middle value lies beyond the limit too.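

Compound 1 and compound 4 both return only a limit in this assay, not a number, so no step between them can be read: the limit of > 10000 nM in this assay, at which 3 of the 4 values shown sit.

Whether 6-methoxypyridin-3-yl in place of 3-methoxyphenyl changes the read-out at all remains open in the compounds shown.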